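The compounds below may be only part of what the source reports. "The series", "measured", "known", "first", "only" and "open" are said of these compounds alone.

Of the compounds shown here, two of one family have been measured so far, and both were weak. Compound 2 `CCCn1c(=O)[nH]c2nc(-c3ccc(S(=O)(=O)N4CCN(c5ccc(I)cc5)CC4)cc3)[nH]c2c1=O` was tested in an assay on CHO cells for displacement of a labelled ligand from adenosine receptor A1 (Homo sapiens), read by scintillation counting, with a stated time of 90 min, in the presence of a further agent that is not named here (a lower number here means a stronger inhibitor, a higher number a weaker inhibitor), and gave only a limit of the assay, > 1000 nM, not a number. Compound 1 `CCCn1c(=O)c2[nH]c(-c3ccc(S(=O)(=O)N4CCN(c5ccc(Cl)cc5)CC4)cc3)nc2n(CC)c1=O` also returned only a limit in this assay, > 1000 nM. The two results therefore share one feature: the limit of > 1000 nM in this assay, at which 2 of the 2 values shown sit. Going by the values given here, because both values are limits, no step between measured compounds can be drawn, and nothing about the size or direction of a structural change within this family is known from measurement.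

Compound 3 `CCCn1c(=O)[nH]c2nc(-c3ccc(S(=O)(=O)N4CCN(c5ccccc5F)CC4)cc3)[nH]c2c1=O` has not yet been tested. It differs from compound 2 in one place: 2-fluorophenyl in place of 4-iodophenyl on an amine nitrogen in a ring. The shared core and the rest of the molecule are unchanged.

With only two limits to go on, the expectation for compound 3 is modest. Compound 3 is estimated to give 2000 nM in this assay, with a likely range from 600 nM to 7000 nM. That estimate means a step that the limit leaves unreadable from compound 2 to compound 3, which is no more than none beyond the usual scatter, and it is expected that the assay may again report only a limit rather than a number.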

Compound 3, inhibition constant: > 1000 nM
Compound 3: a limit, no number; the forecaster's own chance of this, stated with the estimate: 70%; the middle value is on the limit's open side.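

Compound 3 gives > 1000 nM in this assay, a limit and not a number. Going by these compounds alone, compound 2 also gave only a limit, so no step from compound 2 to compound 3 can be read. The compounds shown leave open how strong an inhibitor each one is, and whether 2-fluorophenyl in place of 4-iodophenyl changes that at all.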